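Naphthalenyl Ether Replaces Cyanophenyl in a Rat Whole-Animal Series

A few compounds are considered here, and "the series" means these few. Any claim that something is new, unique, unknown or untested is made for them only; others in the source may bear on it.

Compound 1 `Cc1ccccc1OCC(O)CNCC(=O)Nc1ccc(C2=NNC(=O)CC2)cc1`: 2 umol/kg
Compound 2 `COc1ccccc1OCC(O)CNCC(=O)Nc1ccc(C2=NNC(=O)CC2)cc1`: 4.6 umol/kg
Compound 3 `N#Cc1ccccc1OCC(O)CNCC(=O)Nc1ccc(C2=NNC(=O)CC2)cc1`: 14 umol/kg

In a functional assay on the whole organism with Rattus norvegicus as the target (a lower number here means that less compound is needed, a higher number that more compound is needed for the effect), compound 3 stands highest of the three numbers, with compound 2 nearest and compound 1 furthest. The steps of a 2.3-fold higher number from compound 1 to compound 2 (0.36 log units; beyond the scatter) and a 7.0-fold higher number from compound 1 to compound 3 (0.85 log units; beyond the scatter) show that the group on the aromatic ring attached to the ether oxygen moves the read-out well beyond the scatter. Compound 4 `O=C1CCC(c2ccc(NC(=O)CNCC(O)COc3cccc4ccccc34)cc2)=NN1` carries the change (naphthalen-1-yl in place of 2-cyanophenyl on an oxygen on a saturated carbon). No measured step involves a fused ring system, so the three steps give only the scale of variation this position has shown, not its direction. Compound 4 is therefore expected to fall within the span already covered, with a 2.8-fold lower number from compound 3 to compound 4 (0.45 log units; beyond the scatter) as the estimated step, giving an estimate of 5 umol/kg (range 1.2 umol/kg to 20 umol/kg).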

Compound 4, dose for half-maximal effect: 1.4 umol/kg
Compound 4: middle estimate off by 3.6-fold (0.55 log units), on the high side; low and high end bracket the measured number.
By their numbers in this assay, from the lowest: compounds 4 and 1 (each within the scatter of the next); then compound 2; then compound 3.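

In this assay, a fused ring system on the oxygen is compatible with a low number: naphthalen-1-yl in place of 2-cyanophenyl gives a 10-fold lower number from compound 3 to compound 4 (1.00 log units; beyond the scatter), and in place of 2-methoxyphenyl it gives a 3.3-fold lower number from compound 2 to compound 4 (0.52 log units; beyond the scatter). In place of 2-methylphenyl it gives a 1.4-fold lower number from compound 1 to compound 4 (0.15 log units; within the scatter), so these two groups cannot be told apart here. Nothing available explains the size of these steps. Open, on these data alone, is whether naphthalen-2-yl, or a phenyl ring carrying an amine or a carboxylic acid, would stand with compound 1 and compound 4.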